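One Substituent Exchanged on the Aminomethyl-Bearing Ring

This account rests on a few compounds, and the source may have more. Where it says the series, first, only, none or still open, it means among the compounds named here.

Compound 1 `NCc1ccccc1CN(Cc1nc2ccccc2[nH]1)C1CCCc2cccnc21`: 28 nM
Compound 2 `NCc1cc(C(F)(F)F)ccc1CN(Cc1nc2ccccc2[nH]1)C1CCCc2cccnc21`: 51 nM

Of the compounds shown here, two have been measured in a functional assay on CEM-CCRF cells for antagonist activity at C-X-C chemokine receptor type 4 (Homo sapiens), read by calcium flux; a lower number here means a stronger inhibitor, a higher number a weaker inhibitor. Compound 1 gives 28 nM, and compound 2 gives 51 nM. Among the measured compounds shown here, compound 2 stands at the end of the only measured step, a 1.8-fold higher number from compound 1 to compound 2 (0.26 log units; within the scatter), so it cannot be separated from compound 1: putting a trifluoromethyl onto the ring barely moved the number.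

Compound 3 `CO/N=C/c1ccc(CN(Cc2nc3ccccc3[nH]2)C2CCCc3cccnc32)c(CN)c1` has not yet been measured. Relative to compound 2 the change is a group of 4 heavy atoms (2 carbon, 1 nitrogen, 1 oxygen; no ring) in place of a group of 4 heavy atoms (1 carbon, 3 fluorine; no ring), on an aromatic carbon. The new group sits where the trifluoromethyl was: meta to the aminomethyl group and para to the large group. For the measured compounds named here, the single step that touches this position is a 1.8-fold higher number from compound 1 to compound 2 (0.26 log units; within the scatter), and it stayed within the scatter; no measured step exists for the group that enters, so its effect is unknown. Compound 3 is therefore expected to show a step of a 1.3-fold lower number from compound 2 to compound 3 (0.11 log units; within the scatter), not beyond the scatter. For compound 3 the estimate is 40 nM, expected to lie between 15 nM and 120 nM.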

Compound 3, half-maximal inhibitory concentration: 5 nM
Beside the measured number, compound 3's estimate is 8.0-fold (0.90 log units) above it, and the stated range ends above it.
By their numbers in this assay, from the lowest: compound 3; then compounds 1 and 2 (each within the scatter of the next).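

In this assay the aromatic carbon meta to an aminomethyl group proves sensitive to what it carries: the group of 4 heavy atoms (2 carbon, 1 nitrogen, 1 oxygen; no ring) in place of trifluoromethyl gives a 10-fold lower number from compound 2 to compound 3 (1.01 log units; beyond the scatter) and so makes a large difference. The same group in place of hydrogen gives a 5.6-fold lower number from compound 1 to compound 3 (0.75 log units; beyond the scatter) as a modest gain, which shows that substitution here can go beyond what hydrogen gives, something the trifluoromethyl step within the scatter could not show. The two groups have the same heavy-atom count, so that count does not separate them, and while the entering group has 2 hydrogen-bond acceptors and a double bond outside aromatic rings, nothing available connects either feature to the change in potency.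

Which part of the entering group matters stays open, and a nitrile, an amine, a carboxylic acid or a longer chain on the same carbon would help to narrow that down. Among the compounds shown here, it also remains unknown whether the gain would carry over to a core different from the one shared by these compounds.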